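Phenyl in place of 1,3-benzothiazol-2-yl on compound 1

The compounds below may be only part of what the source reports. "The series", "measured", "known", "first", "only" and "open" are said of these compounds alone.

In an ADME assay on Raji cells (Homo sapiens) for cytotoxicity, with a stated time of 72 h (a lower number here means that less compound is needed, a higher number that more compound is needed for the effect), compound 1 (`O=C(Nc1cccc(-c2nc3ccccc3s2)c1)c1cc([N+](=O)[O-])ccc1Cl`) gives only a limit, > 27000 nM, so it offers no exact starting value. Compound 2 (`COc1ccc(-c2nc3ccccc3s2)cc1NC(=O)c1cc([N+](=O)[O-])ccc1Cl`) likewise gives only a limit, > 25000 nM. Going by the values given here, the one measured step is a step that the two limits leave unreadable from compound 1 to compound 2, and it concerns methoxy in place of hydrogen on an aromatic carbon. Among the compounds with values here, it therefore provides no size to carry over, and no measured step covers the change that leads to compound 3 (`O=C(Nc1cccc(-c2ccccc2)c1)c1cc([N+](=O)[O-])ccc1Cl`). That change is phenyl in place of 1,3-benzothiazol-2-yl on an aromatic carbon, with phenyl in place of 1,3-benzothiazol-2-yl on an aromatic carbon, meta to a large group. With no measured guide to a shift in either direction, no change beyond the scatter is expected in this assay. The estimated step is a number no higher from compound 1 to compound 3 (the limit leaves the size open). For compound 3 the expected value is 27000 nM, with an estimated range from 9000 nM to 60000 nM.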

Compound 3, half-maximal effective concentration: > 27000 nM
Compound 3: no number, only a limit; the forecaster's own chance of this, stated with the estimate: 75%; the middle value lies on the limit itself.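

Going by these compounds alone, compound 1 and compound 3 both give only limits in this assay, so no step between them can be read. The compounds shown leave open the exact value of each, and so whether phenyl in place of 1,3-benzothiazol-2-yl shifts the read-out at all.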